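The source may report more compounds than this note shows. Statements on the series, on what has been measured and on what is new or still open speak of the compounds shown alone.

Compound 1 `CC1=CC[C@H](C(C)(C)NC(=S)N/N=C/c2ccccc2)CC1` is the starting point of this small set. In a functional assay on K562 cells (Homo sapiens) for inhibition, read by sulforhodamine B assay, with a stated time of 48 h (a higher number here means a weaker inhibitor of growth, a lower number a stronger inhibitor of growth), compound 1 gives 47600 nM. Compound 2 `COc1ccc(/C=N/NC(=S)NC(C)(C)[C@H]2CC=C(C)CC2)cc1` carries methoxy in place of hydrogen on an aromatic carbon relative to compound 1; in this assay compound 2 gives 30700 nM, and the step is a 1.6-fold lower number from compound 1 to compound 2 (0.19 log units; within the scatter). Compound 3 `CC1=CC[C@H](C(C)(C)NC(=S)N/N=C/c2ccc(O)cc2)CC1` differs from compound 1 by hydroxy in place of hydrogen on an aromatic carbon. For compound 3 in this assay only a limit was reached, > 100000 nM. Within the data shown here, that limit of > 100000 nM in this assay, at which 1 of the 3 values shown sits, is the only one among the three values. From this follow the steps of an at least 2.1-fold higher number from compound 1 to compound 3 (0.32 log units; beyond the scatter) and an at least 3.2-fold higher number from compound 2 to compound 3 (0.51 log units; beyond the scatter).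

Compound 4 `COc1cc(/C=N/NC(=S)NC(C)(C)[C@H]2CC=C(C)CC2)ccc1O` has not yet been measured in this assay. It differs from compound 3 by methoxy in place of hydrogen on an aromatic carbon. This is the same kind of change as that from compound 1 to compound 2, (methoxy in place of hydrogen on an aromatic carbon), which made a step of a 1.6-fold lower number from compound 1 to compound 2 (0.19 log units; within the scatter); in compound 4, however, the entering group sits ortho to a hydroxy group and meta to a large group, whereas in compound 2 it sits para to a large group. The cores of the two pairs differ by hydroxy in place of hydrogen on an aromatic carbon. For compound 4 a step that the limit leaves unreadable from compound 3 to compound 4 is expected, because the earlier step of a 1.6-fold lower number from compound 1 to compound 2 (0.19 log units; within the scatter) lay within the scatter, while the limit of > 100000 nM in this assay, at which 1 of the 3 values shown sits, leaves the starting point itself uncertain. Compound 4 is therefore expected to give roughly 120000 nM in this assay, most likely between 40000 nM and 400000 nM.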

Compound 4, concentration for total growth inhibition: 85200 nM
Estimate against measurement, compound 4: 1.4-fold (0.15 log units) above; low and high end bracket the measured number.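

In this assay, methoxy in place of hydrogen on an aromatic carbon of the core of compound 3 gives an at least 1.1-fold lower number from compound 3 to compound 4 (0.06 log units; that floor lies within the scatter). Set beside the same change on the core of compound 1, this new step shows no clear gain or loss on either core, but it does not establish that the change carries over with the same size: the same change on two cores in this assay, a 1.6-fold lower number (0.19 log units; within the scatter) from compound 1 to compound 2 and an at least 1.1-fold lower number (0.06 log units; that floor lies within the scatter) from compound 3 to compound 4; the limit leaves it open whether they differ. Compound 3 stands at a limit and not at a number, so the true size of the new step stays unknown, and it also remains unsettled whether the place of the methoxy in compound 4, ortho to a hydroxy group and meta to a large group, has any bearing on that size: the limit of > 100000 nM in this assay, at which 1 of the 4 values shown sits.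

The compounds shown leave open how an amine, a carboxylic acid or a longer alkoxy chain would behave on the same aromatic ring in this assay. They also leave open whether a methoxy group on other carbons of that ring, or a second methoxy group in place of the hydroxy group of compound 4, would shift the number by more than the usual scatter.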